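This account rests on a few compounds, and the source may have more. Where it says the series, first, only, none or still open, it means among the compounds named here.

Compound 1 `C=C(CC)C(=O)c1ccc(OCC(=O)NCCCN2CCCC2=O)c(Cl)c1Cl` is the reference point. Going by the values given here, in a functional assay on CLL cells (Homo sapiens) for cytotoxicity, read by MTT assay, with a stated time of 48 h (on this read-out lower numbers stand for an effect already at smaller amounts and higher numbers for an effect only at larger amounts of compound), compound 1 gives 13800 nM, the highest of the two numbers measured so far. Its nearest neighbour is compound 2 `C=C(CC)C(=O)c1ccc(OCC(=O)NCC2CCC(C(=O)O)CC2)c(Cl)c1Cl`; in this assay compound 2 gives 8000 nM. The step between them is a 1.7-fold lower number from compound 1 to compound 2 (0.24 log units; within the scatter), a change of the group on the amide-type nitrogen that stays within the scatter.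

Compound 3 `C=C(CC)C(=O)c1ccc(OCC(=O)NO)c(Cl)c1Cl` has not yet been measured. It differs from compound 1 by hydroxy in place of 3-(2-oxopyrrolidin-1-yl)propyl on an amide-type nitrogen. Among the compounds with values here, the only measured step that bears on this change is a 1.7-fold lower number from compound 1 to compound 2 (0.24 log units; within the scatter), since it alters the same amide-type nitrogen, and it did not leave the scatter. That single step gives no ground for expecting a move beyond the scatter in either direction, though the change to hydroxy is larger than any step measured. Compound 3 is therefore expected to give about 10000 nM in this assay, within a range from 3000 nM to 40000 nM, an expected step of a 1.4-fold lower number from compound 1 to compound 3 (0.14 log units; within the scatter).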

Compound 3, half-maximal effective concentration: 4500 nM
Compound 3: the middle estimate sits 2.2-fold (0.35 log units) above what was measured; the range from low to high includes it.
By their numbers in this assay, from the lowest: compounds 3, 2 and 1 (each within the scatter of the next, the first and the last beyond it).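

Going by these compounds alone, on the amide-type nitrogen, the step in this assay, a 3.1-fold lower number from compound 1 to compound 3 (0.49 log units; beyond the scatter), is the first change at this place to go beyond the scatter, so the group carried there can shift the number, if only modestly. The much smaller hydroxy, with 1 heavy atom against the 9 heavy atoms and the five-membered ring of 3-(2-oxopyrrolidin-1-yl)propyl, still gives a measurable effect on these cells, so that ring-bearing chain is not required for the effect. Nothing measured here accounts for the shift.

As far as these compounds go, whether the shift belongs to the hydroxy itself or to the loss of the 3-(2-oxopyrrolidin-1-yl)propyl stays open. A methoxy or a methyl on the same amide-type nitrogen, or a plain amide hydrogen there, would bear on that question.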